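Fluorine Added to the Aryl Ring: Plasma Free Fraction

The source may hold more compounds than are shown below. What is called first, only, known or untested is meant among the compounds shown, and "the series" means these compounds.

Measured compounds:
Compound 1 `COc1c(F)cccc1C1CCN(c2ccn3c(CC(F)(F)F)nnc3c2C#N)CC1`, in an ADME assay on a cell-free system (plasma, Homo sapiens) for protein binding (on this read-out higher numbers stand for a larger free fraction and lower numbers for a smaller free fraction), compound 1 gives 0.047.
Compound 2 `COc1c(F)cccc1C1CCN(c2ccn3c(CC4CC4)nnc3c2Cl)CC1`, in this assay compound 2 gives < 0.01.

The value for compound 2 is a limit of the assay, not a number. Compound 2 therefore sits at the lower edge of what is shown, and only compound 1 carries a numeric value. Going by the values given here, the one point of evidence is the limit of < 0.01 in this assay, at which 1 of the 2 values shown sits, which places compound 2 at the floor of the read-out.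

Compound 3 `COc1cc(F)cc(F)c1C1CCN(c2ccn3c(CC4CC4)nnc3c2Cl)CC1` follows from compound 2 by 2,4-difluoro-6-methoxyphenyl in place of 3-fluoro-2-methoxyphenyl on a saturated ring carbon. Among the compounds with values here, no measured step is available for this kind of change, so no step beyond the scatter is expected in this assay. Compound 3 is expected to give about 0.006, between 0.002 and 0.015. The expected step from compound 2 to compound 3 is a step that the limit leaves unreadable from compound 2 to compound 3.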

Compound 3, unbound fraction: < 0.01
Compound 3 ended at the assay's limit; the forecaster's own chance of this, stated with the estimate: 70%; the middle value lies beyond the limit too.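

Compound 2 and compound 3 both end at a limit of this assay rather than at a number, so no step can be read between them: the limit of < 0.01 in this assay, at which 2 of the 3 values shown sit.

The compounds shown leave open whether 2,4-difluoro-6-methoxyphenyl in place of 3-fluoro-2-methoxyphenyl shifts the free fraction at all, and if so, in which direction and how far.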